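Amide nitrogen swap from compound 1 to compound 4

This account rests on a few compounds, and the source may have more. Where it says the series, first, only, none or still open, it means among the compounds named here.

Values in an assay on isolated protein for inhibition of phosphodiesterase 4A (Sus scrofa); a lower number here means a stronger inhibitor, a higher number a weaker inhibitor:
compound 1, `COc1ccc(C(=O)Nc2ccccc2Cl)cc1OC1CCCC1`, 190 nM
compound 2, `COc1ccc(C(=O)Nc2ccccc2Cl)cc1OC`, 650 nM
compound 3, `COc1ccc(C(=O)Nc2ccccc2Cl)cc1OC(C)=O`, 70000 nM

Compound 1 stands lowest of the three measured numbers. The nearest is a 3.4-fold higher number from compound 1 to compound 2 (0.53 log units; beyond the scatter), the furthest a 370-fold higher number from compound 1 to compound 3 (2.57 log units; beyond the scatter), and between the other two a 110-fold higher number from compound 2 to compound 3 (2.03 log units; beyond the scatter). All three steps alter the group on the aromatic oxygen and leave the amide nitrogen untouched.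

Compound 4, `COc1ccc(C(=O)Nc2nccs2)cc1OC1CCCC1`, differs from compound 1 at that nitrogen: 1,3-thiazol-2-yl in place of 2-chlorophenyl on an amide-type nitrogen. For the measured compounds named here, no measured step covers this change, so the series gives no size or direction for it. The working assumption is a step no larger than the scatter, with some allowance for weakening. The step is expected to be a 1.6-fold higher number from compound 1 to compound 4 (0.20 log units; within the scatter). The estimate for compound 4 is 300 nM, ranging from 60 nM to 1500 nM.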

Compound 4, half-maximal inhibitory concentration: 6500 nM
For compound 4 the middle estimate is 22-fold (1.34 log units) below the measured one; the whole stated range lies below it.
By their numbers in this assay, from the lowest: compound 1; then compound 2; then compound 4; then compound 3.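

The step of a 34-fold higher number from compound 1 to compound 4 (1.53 log units; beyond the scatter) in this assay shows that the group on the amide-type nitrogen is not a silent position. Until now only the group on the aromatic oxygen had been seen to move the number, so this is a second place on the core of compound 1 where one change gives a large step. Nothing shown bears on what lies behind this step. Still open, as far as these compounds go, is whether the loss goes with the thiazole ring or with losing the chlorine-bearing ring. Plain phenyl or pyridin-2-yl on that nitrogen would help separate the two.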